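The source may hold more compounds than are shown below. What is called first, only, known or untested is meant among the compounds shown, and "the series" means these compounds.

Compound 1 `CCC1C(=O)N(C)c2cnc(-n3ccc4cc(C(=O)NC(C)C)ccc43)nc2N1c1ccn(C)n1`: 12200 nM
Compound 2 `CCCCNS(=O)(=O)c1ccc(Nc2ncc3c(n2)N(C2CCCC2)[C@H](CC)C(=O)N3C)cc1`: 1610 nM

In a functional assay on NCI-H1975 cells (Homo sapiens) for antiproliferative activity, read by CCK-8 assay, with a stated time of 72 h (a lower number here means a stronger inhibitor of growth, a higher number a weaker inhibitor of growth), compound 1 holds the higher of the two numbers, and compound 2 lies lower by more than the usual scatter. Compound 3 `CCC1C(=O)N(C)c2cnc(-n3ccc4cc(C(=O)NCC(C)C)ccc43)nc2N1c1ccn(C)n1` keeps the core of compound 1 but has isobutyl in place of isopropyl on an amide-type nitrogen. Within the data shown here, no measured pair shows this change, so the expectation starts from compound 1 at 12200 nM and from how small the change is. The expected step is a 1.2-fold lower number from compound 1 to compound 3 (0.09 log units; within the scatter), with nothing beyond the scatter anticipated in this assay. For compound 3 the estimated value is 10000 nM, with an expected range of 4500 nM to 22000 nM.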

Compound 3, concentration for 50% growth inhibition: 10200 nM
Estimate against measurement, compound 3: 1.0-fold (0.01 log units) below, within the range that was stated.
By their numbers in this assay, from the lowest: compound 2; then compounds 3 and 1 (each within the scatter of the next).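

In this assay, isobutyl in place of isopropyl on an amide-type nitrogen gives a 1.2-fold lower number from compound 1 to compound 3 (0.08 log units; within the scatter), so this change on the core of compound 1 does not separate the two compounds. At this position, the isopropylcarbamoyl and isobutylcarbamoyl forms therefore read alike in this assay. No measured evidence bears on the reason for this result. The compounds shown leave open whether a much longer chain on this nitrogen would give a number beyond the scatter from compound 1. They also leave open what an amine or a carboxylic acid at the end of that chain would do.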